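A Sulfanyl Swap in a Level Half-Life Series

The source may hold more compounds than are shown below. What is called first, only, known or untested is meant among the compounds shown, and "the series" means these compounds.

In an in vitro ADME assay on microsomes (Rattus norvegicus) for metabolic stability (on this read-out higher numbers stand for a longer-lived compound and lower numbers for a shorter-lived compound), compound 1 `CCc1nc(-c2ccc(Cl)cc2Cl)c(CC)nc1NC(COC)COC` gives 0.0417 h, compound 2 `CCc1nc(-c2ccc(Cl)cc2Cl)c(CC)nc1NC(C1CC1)C1CC1` gives 0.0417 h and compound 3 `CCc1nc(-c2ccc(Cl)cc2Cl)c(CC)nc1CC(CC)CC` gives 0.0417 h, so compound 3 stands level with the other two. Compound 4 `CCc1nc(-c2ccc(Cl)cc2Cl)c(CC)nc1SC(C)CC` carries (sec-butyl)sulfanyl in place of 2-ethylbutyl on an aromatic carbon. For the measured compounds named here, no measured step tests this sulfanyl group. The closest evidence is no change at the digits printed from compound 1 to compound 3 (within the scatter) and no change at the digits printed from compound 2 to compound 3 (within the scatter), both swaps on an aromatic carbon, together with no change at the digits printed from compound 1 to compound 2 (within the scatter). All three lie within the scatter, so no step beyond the scatter is expected in this assay. The estimated step is no change at the digits printed from compound 3 to compound 4 (within the scatter). Compound 4 is expected at 0.0417 h, within an estimated range from 0.025 h to 0.09 h.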

Compound 4, half-life: 0.0683 h
Compound 4: middle estimate off by 1.6-fold (0.21 log units), on the low side; measured number inside the range.
By their numbers in this assay, from the lowest: compounds 1, 2, 3 and 4 (each within the scatter of the next).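

In this assay the sulfur-linked (sec-butyl)sulfanyl group, on the aromatic carbon para to a 2,4-dichlorophenyl group, gives a 1.6-fold higher number from compound 3 to compound 4 (0.21 log units; within the scatter), with a 1.6-fold higher number from compound 2 to compound 4 (0.21 log units; within the scatter) and a 1.6-fold higher number from compound 1 to compound 4 (0.21 log units; within the scatter) as the matching swaps. A sulfur link at this position therefore stays within the scatter of the carbon-linked 2-ethylbutyl group and both amino-linked groups. No evidence is available to explain this result. The compounds shown leave open whether a sulfonyl in place of the sulfanyl, a sec-butoxy group or a longer chain on sulfur would also stay within the scatter.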